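The source may hold more compounds than are shown below. What is called first, only, known or untested is meant among the compounds shown, and "the series" means these compounds.

Compound 1, `Nc1ncc(-c2cccc(Cl)c2)c(-c2ccccc2)n1`, in an assay on CHO cells for displacement of a labelled ligand from adenosine receptor A1 (Homo sapiens), read by scintillation counting, with a stated time of 1 h, tested at 1 uM; on this read-out higher numbers stand for more inhibition at the one concentration tested (going by the name of the read-out) and lower numbers for less inhibition: > 80%, a limit of the assay rather than a number.
Compound 2, `COc1ccc(-c2cnc(N)nc2-c2ccccc2)cc1`: 56%.
Compound 3, `Nc1ncc(-c2ccc(OCc3ccccc3)c(Cl)c2)c(-c2ccccc2)n1`: 38%.

Compound 1 stands at the limit of this assay, (the limit of > 80% in this assay, at which 1 of the 3 values shown sits). Within the data shown here, compound 2 and compound 3 sit well under that limit, and the one measured step, a number at least 42 percentage points lower from compound 1 to compound 3 (beyond the scatter), concerns a group on an aromatic carbon, so it says nothing direct about the amino nitrogen. Compound 4, `OCCCCNc1ncc(-c2cccc(Cl)c2)c(-c2ccccc2)n1`, has not yet been measured in this assay; it differs from compound 1 in that (4-hydroxybutyl in place of hydrogen on a nitrogen on an aromatic ring). Among the measured compounds shown here, no measured step touches that nitrogen, so the expectation rests only on where compound 1 stands: at the top of the range, any change there can be read as holding or lowering, not raising. A moderate drop is expected, a number at least 25 percentage points lower from compound 1 to compound 4 (beyond the scatter), with wide uncertainty on either side. Compound 4 is therefore estimated at 55%, between 20% and 85%.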

Compound 4, a percentage reported as inhibition, at one concentration (the size of the read-out at that concentration, not a potency): > 80%
Compound 4: no number, only a limit; the forecaster's own chance of this, stated with the estimate: 15%; middle value at least 25 percentage points away from the limit.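

Compound 4 gives > 80% in this assay as a limit, not a number. Among these compounds, compound 1 and compound 4 both stand at the limit, so no step between them can be read: the limit of > 80% in this assay, at which 2 of the 4 values shown sit.
The compounds shown leave open whether 4-hydroxybutyl in place of hydrogen on that nitrogen changes the inhibition at all, and in which direction.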